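The source may hold more compounds than are shown below. What is called first, only, known or untested is meant among the compounds shown, and "the series" means these compounds.

Measured so far:
Compound 1 `Cc1ccccc1S(=O)(=O)N[C@H]1C2CC[C@H](C2)[C@@H]1C/C=C\CCCC(=O)O`: 6200 nM
Compound 2 `CCCCCc1ccc(S(=O)(=O)N[C@H]2C3CC[C@H](C3)[C@@H]2C/C=C\CCCC(=O)O)cc1`: 800000 nM

Both were tested in a functional assay (plasma) for inhibition, with Oryctolagus cuniculus as the target; a higher number here means a weaker inhibitor, a lower number a stronger inhibitor. In this assay compound 1 gives 6200 nM, the lower of the two numbers, while compound 2 gives 800000 nM, a gap well beyond the scatter, so compound 1 stands as the stronger inhibitor of the pair. Compound 3 `CS(=O)(=O)N[C@H]1C2CC[C@H](C2)[C@@H]1C/C=C\CCCC(=O)O` is not yet measured. It differs from compound 1 in one place: methyl in place of 2-methylphenyl on a sulfonyl sulfur. Among the compounds with values here, no measured pair shows this change, so its size is unknown; a step to a weaker inhibitor beyond the scatter is expected, a 6.5-fold higher number from compound 1 to compound 3 (0.81 log units; beyond the scatter). Compound 3 is estimated at 40000 nM, within 6000 nM to 300000 nM.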

Compound 3, half-maximal inhibitory concentration: 640000 nM
Beside the measured number, compound 3's estimate is 16-fold (1.20 log units) below it; the measured number lies above the stated range.
By their numbers in this assay, from the lowest: compound 1; then compounds 3 and 2 (each within the scatter of the next).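

Swapping 2-methylphenyl for methyl on the sulfonyl sulfur gives a 100-fold higher number from compound 1 to compound 3 (2.01 log units; beyond the scatter) in this assay. So on the shared core, inhibition depends heavily on what sits at this position, and a methyl does not stand in for the 2-methylphenyl of compound 1. Nothing available here explains the size of this step. The change removes the aromatic ring and its methyl together, so their separate contributions cannot be told apart. On these data alone, whether an unsubstituted phenyl or a short chain such as butyl would keep the inhibition of compound 1 remains open.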